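A few compounds are considered here, and "the series" means these few. Any claim that something is new, unique, unknown or untested is made for them only; others in the source may bear on it.

Compound 1 `COc1cc(Nc2nc(C(=N)Nc3ccc(N4CCN(C)CC4)cc3)cc3c(-c4ccccc4)n[nH]c23)cc(OC)c1OC` was examined in a functional assay on MDA-MB-231 cells (Homo sapiens) for cytotoxicity, read by MTT assay, with a stated time of 72 h (on this read-out lower numbers stand for stronger inhibition and higher numbers for weaker inhibition), where compound 1 gives 4600 nM. Going by the values given here, the only other measured compound, compound 2 `N=C(Nc1cccc(C(F)(F)F)c1)c1cc2c(-c3ccccc3)n[nH]c2cn1`, gives 22300 nM in this assay, so compound 1 holds the lower of the two numbers, and its gap to compound 2 lies beyond the scatter. Compound 3 `COc1cc(Nc2nc(C(=N)Nc3ccccc3)cc3c(-c4ccccc4)n[nH]c23)cc(OC)c1OC` has not yet been measured. It differs from compound 1 by hydrogen in place of 4-methylpiperazin-1-yl on an aromatic carbon of a six-membered aromatic ring of carbon only, para to a large group. Among the compounds with values here, no measured pair shows this exact change, so its size cannot be read from the data. The author expects a small shift toward a higher number, a 1.7-fold higher number from compound 1 to compound 3 (0.24 log units; within the scatter), not far beyond the scatter. For compound 3 in this assay the author therefore estimates 8000 nM, with a range from 3000 nM to 25000 nM.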

Compound 3, half-maximal inhibitory concentration: 4500 nM
For compound 3 the middle estimate is 1.8-fold (0.25 log units) above the measured one, and the stated range covers the measured number.
By their numbers in this assay, from the lowest: compounds 3 and 1 (each within the scatter of the next); then compound 2.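

In this assay, replacing 4-methylpiperazin-1-yl with hydrogen on this aromatic carbon, para to a large group, gives a 1.0-fold lower number from compound 1 to compound 3 (0.01 log units; within the scatter). Going by these compounds alone, this is the first comparison in the set that isolates a single place, and it shows that the whole group, with its six-membered non-aromatic ring, can be exchanged for hydrogen here without a step beyond the scatter. No available measurement explains why this step is so small.

The compounds shown carry only hydrogen and 4-methylpiperazin-1-yl at this carbon, so the effect of a morpholine ring, a carboxylic acid or a longer amine chain there remains open. On these data alone, whether the same exchange would be equally small on another core also remains open.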